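A few compounds are considered here, and "the series" means these few. Any claim that something is new, unique, unknown or untested is made for them only; others in the source may bear on it.

Compound 3 `N#CC1=C(N)Oc2c(N)cc3nc4ccccc4nc3c2C12C(=O)N(Cc1cnnn1-c1ccc(F)cc1)c1ccccc12` stands at the edge of what an ADME assay on L02 cells (Homo sapiens) for antiproliferative activity, read by MTT assay, with a stated time of 48 h (on this read-out higher numbers stand for weaker inhibition and lower numbers for stronger inhibition), can report: in this assay compound 3 gives > 50000 nM, which is a limit of the assay and not a number. Compound 1 `COc1ccc(-n2nncc2CN2C(=O)C3(C(C#N)=C(N)Oc4c3c3nc5ccccc5nc3c3ccccc43)c3ccccc32)cc1` is at the same kind of limit, giving > 50000 nM in this assay. Compound 2 `Cc1ccc(-n2nncc2CN2C(=O)C3(C(C#N)=C(N)Oc4c3c3nc5ccccc5nc3c3ccccc43)c3ccccc32)cc1C` in this assay likewise gives > 50000 nM, again a limit. Within the data shown here, all three values shown sit at one point, (the limit of > 50000 nM in this assay, at which 3 of the 3 values shown sit), so the only step between measured compounds, a step that the two limits leave unreadable from compound 1 to compound 2, cannot be read in size or direction. Compound 4 `COc1ccc(-n2nncc2CN2C(=O)C3(C(C#N)=C(N)Oc4c(N)cc5nc6ccccc6nc5c43)c3ccccc32)cc1` differs from compound 3 by methoxy in place of fluoro on an aromatic carbon. No measured step bears on a change of this kind here, and the one step that exists is unreadable; the shared core has not shown a numerical value in any of the three compounds. Compound 4 is therefore expected to stay at the limit as well, with an estimated value of 70000 nM and a range from 25000 nM to 200000 nM. The expected step that the limit leaves unreadable from compound 3 to compound 4 is thus estimated to be none beyond the scatter.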

Compound 4, half-maximal inhibitory concentration: > 50000 nM
Compound 4 was reported as a limit; the forecaster's own chance of this, stated with the estimate: 85%; the middle value lies beyond the limit too.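

In this assay, no step can be read from compound 3 to compound 4, because both stand at a limit of the assay and not at a number: the limit of > 50000 nM in this assay, at which 4 of the 4 values shown sit. The compounds shown leave open how 4-fluorophenyl and 4-methoxyphenyl compare, and where any of these compounds lies beyond that limit.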